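The source may hold more compounds than are shown below. What is called first, only, known or untested is meant among the compounds shown, and "the series" means these compounds.

Compound 3 `CCCS(=O)(=O)Nc1ccc(F)c(C(=O)c2n[nH]c3ncc(-c4ccc(C(F)(F)F)cc4)cc23)c1F` stands at the highest number of the three compounds measured in an assay for binding affinity to dual specificity mitogen-activated protein kinase kinase 4 (Homo sapiens), read by KINOMEscan, tested at 100 nM; a higher number here means a weaker effect of the compound at the concentration tested, a lower number a stronger effect: compound 3 gives 29%, while compound 1 `CCCS(=O)(=O)Nc1ccc(F)c(C(=O)c2n[nH]c3ncc(-c4cccc(C)c4)cc23)c1F` gives 15% and compound 2 `CCCS(=O)(=O)Nc1ccc(F)c(C(=O)c2n[nH]c3ncc(-c4ccc(Cl)c(C(F)(F)F)c4)cc23)c1F` gives 15%. The two steps leading to compound 3, a number 14 percentage points higher from compound 1 to compound 3 (beyond the scatter) and a number 14 percentage points higher from compound 2 to compound 3 (beyond the scatter), both lie beyond the scatter, whereas the step between the other two, no change at the digits printed from compound 1 to compound 2 (within the scatter), does not. Compound 4 `CCCS(=O)(=O)Nc1ccc(F)c(C(=O)c2n[nH]c3ncc(-c4ccc(-c5nnn[nH]5)cc4)cc23)c1F` has not yet been measured in this assay. It differs from compound 3 in one place: 1H-tetrazol-5-yl in place of trifluoromethyl on an aromatic carbon. Among the measured compounds shown here, the measured steps all swap the whole aryl ring attached to the shared core, and none of them brings in a 1H-tetrazol-5-yl anywhere, so no step bears directly on this change. What the measured steps do show is that changing the group on that ring moves the number in this assay by modest amounts, and in either direction depending on the group. Without a closer precedent, the step expected from compound 3 to compound 4 is a number 1 percentage points higher from compound 3 to compound 4 (within the scatter), small and of uncertain direction, with wide uncertainty. Compound 4 is therefore estimated at 30%, within a range from 10% to 60%.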

Compound 4, a percentage reported as activity, at one concentration (the size of the read-out at that concentration, not a potency): 0.15%
Estimate against measurement, compound 4: 29.9 percentage points above, outside the stated range (below it).
By their numbers in this assay, from the lowest: compound 4; then compounds 1 and 2 (each within the scatter of the next); then compound 3.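

In this assay, among the compounds shown here, the group on the para position of the aryl ring matters more than the earlier compounds showed: placing 1H-tetrazol-5-yl where trifluoromethyl stood gives a number 28.9 percentage points lower from compound 3 to compound 4 (beyond the scatter), a larger step than any seen before, and moves the series from its highest number to its lowest. The whole 4-(1H-tetrazol-5-yl)phenyl group also outperforms the other two rings, with a number 14.9 percentage points lower from compound 2 to compound 4 (beyond the scatter) and a number 14.9 percentage points lower from compound 1 to compound 4 (beyond the scatter), so compound 4 has the strongest effect of the four at the concentration tested, and this position clearly accepts a five-membered aromatic ring with 4 hetero atoms. Nothing measured here explains why this swap produces such a gain.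

The compounds shown leave open whether a carboxylic acid or a primary amide on the same ring carbon would give a number as low, and whether 1H-tetrazol-5-yl would do the same elsewhere on the phenyl ring. From the compounds shown here alone, these readings come from a single concentration, so the real difference in potency between the compounds also remains open.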